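The source may report more compounds than this note shows. Statements on the series, on what has been measured and on what is new or still open speak of the compounds shown alone.

Of the compounds shown here, two have so far been measured in an assay on A10 cells for antagonist activity at Endothelin-1 receptor (Rattus norvegicus); on this read-out higher numbers stand for weaker inhibition and lower numbers for stronger inhibition. Compound 1, `N#Cc1ccc(OCc2ccsc2)cc1OC(C(=O)O)c1ccc(Cl)cc1`, gives 504 nM in this assay. Compound 2, `Cc1ccccc1C(Oc1cc(OCc2ccc3c(c2)OCCO3)ccc1C#N)C(=O)O`, gives 1500 nM in this assay, which is the higher of the two numbers; its nearest neighbour is compound 1, whose number is lower by a gap that lies beyond the usual scatter of repeated measurements.

Compound 3, `Cc1ccccc1C(Oc1cc(OCc2ccc3ncoc3c2)ccc1C#N)C(=O)O`, has not yet been measured. It differs from compound 2 in one place: 1,3-benzoxazol-6-yl in place of 2,3-dihydro-1,4-benzodioxin-6-yl on a saturated chain carbon bound to an oxygen on an aromatic ring. Within the data shown here, no pair of measured compounds differs in a single place, so the data give no direct measure of how a swap of this kind moves the read-out, and the two measured compounds differ from each other in several places at once.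

The expectation for the step from compound 2 to compound 3 in this assay is therefore one of no change beyond the scatter, a 1.3-fold lower number from compound 2 to compound 3 (0.10 log units; within the scatter), with the direction left open. On that basis compound 3 is estimated to give 1200 nM in this assay, within a range from 400 nM to 4000 nM.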

Compound 3, half-maximal inhibitory concentration: 6 nM
The estimate for compound 3 lay 200-fold (2.30 log units) above the measured number, and the stated range ends above it.
By their numbers in this assay, from the lowest: compound 3; then compound 1; then compound 2.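

In this assay, among these compounds, putting 1,3-benzoxazol-6-yl in place of 2,3-dihydro-1,4-benzodioxin-6-yl on a saturated chain carbon bound to an oxygen on an aromatic ring gives a 250-fold lower number from compound 2 to compound 3 (2.40 log units; beyond the scatter), the first change at a single place in this set, and it shows that the read-out is highly sensitive to the group held at this position. The size of the step stands out against how much the two groups share: both carry a six-membered aromatic ring of carbon only, neither has a net charge or a hydrogen-bond donor, and both have 2 hydrogen-bond acceptors. What does change is that a six-membered non-aromatic ring with 2 hetero atoms gives way to a five-membered aromatic ring with 2 hetero atoms, and no available measurement explains why this change has so large an effect.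

The compounds shown do not reveal which feature of the new ring accounts for the step, a question that 1,3-benzothiazol-6-yl, with sulfur in place of the ring oxygen, or a plain phenyl group could help to answer. Going by these compounds, it also remains open whether 1,3-benzoxazol-6-yl would give a similar step on the core of compound 1.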